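A few compounds are considered here, and "the series" means these few. Any claim that something is new, unique, unknown or untested is made for them only; others in the source may bear on it.

Compound 2 `COc1cc(OCC(=O)Nc2cccc(NC(=O)c3ccc(N(C)C)cc3)c2)ccc1C=O` gives the lower of the two numbers measured in an assay on isolated protein for inhibition of Rho-associated protein kinase 2 (Homo sapiens), read by scintillation counting, radiometric assay and 33P incorporation, with a stated time of 40 min, in the presence of a further agent that is not named here (a lower number here means a stronger inhibitor, a higher number a weaker inhibitor), at 306 nM. Compound 1 `COc1cccc(OCC(=O)Nc2cccc(NC(=O)c3ccc(N(C)C)cc3)c2)c1`, in this assay, gives 5740 nM; the change between them, formyl in place of hydrogen on an aromatic carbon, brought a 19-fold lower number from compound 1 to compound 2 (1.27 log units; beyond the scatter). Compound 3 `CC(=O)c1ccc(OCC(=O)Nc2cccc(NC(=O)c3ccc(N(C)C)cc3)c2)cc1F` differs from compound 2 by a group of 10 heavy atoms (8 carbon, 1 oxygen, 1 fluorine; one six-membered aromatic ring of carbon only) in place of a group of 10 heavy atoms (8 carbon, 2 oxygen; one six-membered aromatic ring of carbon only), on an oxygen on a saturated carbon. Among the measured compounds shown here, the only step in hand bears on the carbonyl-bearing ring, and it was large, but no step shows what the fluorine does where the methoxy stood. Compound 3 is therefore expected to give 500 nM, between 100 nM and 3000 nM, a step of a 1.6-fold higher number from compound 2 to compound 3 (0.21 log units; within the scatter).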

Compound 3, half-maximal inhibitory concentration: 98 nM
The estimate for compound 3 lay 5.1-fold (0.71 log units) above the measured number, and the stated range ends above it.
By their numbers in this assay, from the lowest: compound 3; then compound 2; then compound 1.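

In this assay, 4-acetyl-3-fluorophenyl on the oxygen on a saturated carbon gives a 3.1-fold lower number from compound 2 to compound 3 (0.49 log units; beyond the scatter), so neither the methoxy nor the formyl of compound 2 is needed to reach a low number here. Among the compounds shown here, replacing the 3-methoxyphenyl of compound 1 outright gives a 59-fold lower number from compound 1 to compound 3 (1.77 log units; beyond the scatter), the largest step so far. No measurement on hand explains either step.

Acetyl and fluorine entered together, so what each contributes alone stays open. Also open, as far as these compounds go, is what an amine or a carboxylic acid would do in the acetyl's place.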